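Amino on a ring nitrogen across two fused cores

A few compounds are considered here, and "the series" means these few. Any claim that something is new, unique, unknown or untested is made for them only; others in the source may bear on it.

Measured in a functional assay on MCF7 cells (Homo sapiens) for antiproliferative activity, read by MTT assay, with a stated time of 48 h; a higher number here means a weaker inhibitor, a lower number a stronger inhibitor:
Compound 1, `Cc1ccc(-c2nc3ccc(Cl)cc3c(=O)[nH]2)cc1`: 4.98 ug/mL
Compound 2, `Cc1ccc(-c2nc3ccc(Cl)cc3c(=S)[nH]2)cc1`: 3.35 ug/mL
Compound 3, `Cc1ccc(-c2nc3ccc(Cl)cc3c(=O)n2N)cc1`: 5.39 ug/mL

Compound 3 is obtained from compound 1 by amino in place of hydrogen on an aromatic nitrogen, and the step is a 1.1-fold higher number from compound 1 to compound 3 (0.03 log units; within the scatter). The difference between the cores of compound 1 and compound 2 is not broken down here; their values in this assay lie close together, as do those of compound 2 and compound 3.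

Compound 4, `Cc1ccc(-c2nc3ccc(Cl)cc3c(=S)n2N)cc1`, is not yet measured. It is obtained from compound 2 by amino in place of hydrogen on an aromatic nitrogen, the same change at the same place as that made from compound 1 to compound 3. Going by the values given here, the expected step in this assay is a 1.1-fold higher number from compound 2 to compound 4 (0.04 log units; within the scatter), placed beside a 1.1-fold higher number from compound 1 to compound 3 (0.03 log units; within the scatter), which is the only measured instance of this change and rests on compound 1 and compound 3 alone. Compound 4 is therefore estimated at 3.7 ug/mL, expected between 2 ug/mL and 7 ug/mL.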

Compound 4, half-maximal inhibitory concentration: 9.25 ug/mL
The estimate for compound 4 lay 2.5-fold (0.40 log units) below the measured number; the whole stated range lies below it.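

Amino in place of hydrogen on an aromatic nitrogen gives a 2.8-fold higher number from compound 2 to compound 4 (0.44 log units; beyond the scatter) in this assay, a modest step. Going by these compounds alone, although only this step lies beyond the scatter, the gap between the two instances of the change does not, so the data do not show that the change behaves differently on the two cores: the same change on two cores in this assay, a 1.1-fold higher number (0.03 log units; within the scatter) from compound 1 to compound 3 and a 2.8-fold higher number (0.44 log units; beyond the scatter) from compound 2 to compound 4, 2.6-fold (0.41 log units) apart, within the scatter of two such steps With one instance per core, this neither establishes that the step carries over from one core to the other nor explains why its printed size is larger here.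

The compounds shown leave open whether a methyl group or a longer chain on the same ring nitrogen would behave as amino does. As far as these compounds go, whether the step holds on cores carrying another group in place of the chlorine also remains open.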